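A few compounds are considered here, and "the series" means these few. Any claim that something is new, unique, unknown or untested is made for them only; others in the source may bear on it.

Compound 1 `Nc1ncnc2c1c(-c1cnc3[nH]ccc3c1)nn2CCCC(=O)NO` gives in a functional assay on CNE-2 cells (Homo sapiens) for inhibition, read by MTT assay, with a stated time of 72 h (on this read-out higher numbers stand for weaker inhibition and lower numbers for stronger inhibition), a value of > 150000 nM, which is a limit of the assay and not a number. Compound 2 `Nc1nc2cc(-c3nn(CC(=O)NO)c4ncnc(N)c34)ccc2o1` gives in this assay 12200 nM. Compound 3 `Nc1nc2cc(-c3nn(CCC(=O)NO)c4ncnc(N)c34)ccc2o1` gives in this assay > 150000 nM, again a limit and not a number.

Compound 1 thus stands at the limit of this assay; only a limit is known for it, and no number places it among the others. Within the data shown here, the one step measured between neighbours that differ in a single place runs an at least 12-fold higher number from compound 2 to compound 3 (1.08 log units; beyond the scatter), the change being (hydroxycarbamoyl)methyl in place of hydroxycarbamoyl on a saturated chain carbon bound to an aromatic nitrogen. Compound 4 `CNC(=O)CCCCCCCn1nc(-c2cnc3[nH]ccc3c2)c2c(N)ncnc21` differs from compound 1 by 4-(methylcarbamoyl)butyl in place of hydroxycarbamoyl on a saturated chain carbon, three bonds along the chain from an aromatic nitrogen. That is not the measured change: hydroxycarbamoyl leaves and 4-(methylcarbamoyl)butyl enters, so the step from compound 2 to compound 3 bears on it only loosely, showing that a variation on the hydroxycarbamoyl side of the same core did not move the number off the limit. Because (the limit of > 150000 nM in this assay, at which 2 of the 3 values shown sit), a result at the limit is the likeliest outcome for compound 4. Compound 4 is therefore expected to give about 200000 nM, between 50000 nM and 600000 nM. The expected step that the limit leaves unreadable from compound 1 to compound 4 means no change that can be spoken of beyond the scatter.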

Compound 4, half-maximal inhibitory concentration: 8990 nM
The estimate for compound 4 lay 22-fold (1.35 log units) above the measured number; measured number below the stated range.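

In this assay, putting 4-(methylcarbamoyl)butyl in place of hydroxycarbamoyl, on a saturated chain carbon, three bonds along the chain from an aromatic nitrogen, gives an at least 16-fold lower number from compound 1 to compound 4 (1.22 log units; beyond the scatter). Among these compounds, the only step known before, an at least 12-fold higher number from compound 2 to compound 3 (1.08 log units; beyond the scatter), ran towards the limit, whereas this one leads away from it and gives the first evidence that a change at this position can bring the core of compound 1 to a readable number, with no hydroxycarbamoyl group present in compound 4. The true size of the step remains unknown, because the starting point is a limit and not a number: the limit of > 150000 nM in this assay, at which 2 of the 4 values shown sit.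

The change replaces the hydroxycarbamoyl end with a methylcarbamoyl end and lengthens the chain in a single step, so the compounds shown do not separate the effect of the end group from that of the chain length. Going by these compounds, that question stays open until the core of compound 1 is seen with a longer chain still ending in hydroxycarbamoyl, with the original short chain ending in methylcarbamoyl, or with a chain ending in a carboxylic acid.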